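This account rests on a few compounds, and the source may have more. Where it says the series, first, only, none or still open, it means among the compounds named here.

Compound 1 `CC(C)c1ccc(-c2nc(SCc3cn(CC(=O)NC(=O)Nc4ccccn4)nn3)nc(Nc3ccc(Cl)cc3)c2C#N)cc1` in a functional assay on MGC-803 cells (Homo sapiens) for inhibition, read by MTT assay, with a stated time of 72 h; on this read-out higher numbers stand for weaker inhibition and lower numbers for stronger inhibition: > 64000 nM
Compound 2 `CC(C)c1ccc(-c2nc(SCc3cn(CC(=O)NC(=O)Nc4ccccn4)nn3)nc(Nc3ccccc3F)c2C#N)cc1` in this assay: > 64000 nM

Compound 1 gives > 64000 nM in this assay, which is a limit of the assay rather than a number. Compound 2 likewise gives > 64000 nM in this assay, again only a limit. Where compound 1 stands cannot be fixed on the numbers shown, since both values sit at the limit of > 64000 nM in this assay, at which 2 of the 2 values shown sit. The step that the two limits leave unreadable from compound 1 to compound 2, 2-fluorophenyl in place of 4-chlorophenyl on a nitrogen on an aromatic ring, stays unreadable between the two limits.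

Compound 3 `CC(C)c1ccc(-c2nc(SCc3cn(CC(=O)NC(=O)Nc4ccccn4)nn3)nc(Nc3ccccc3)c2C#N)cc1` differs from compound 1 by hydrogen in place of chloro on an aromatic carbon of a six-membered aromatic ring of carbon only, para to a large group. Going by the values given here, only the step from compound 1 to compound 2 bears on this change, and it yields no readable size, so no direction beyond the scatter can be derived. The step of a number no higher from compound 1 to compound 3 (the limit leaves the size open) is therefore expected to stay within the scatter, leaving compound 3 at the limit. The estimate for compound 3 is 64000 nM, ranging from 20000 nM to 200000 nM.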

Compound 3, half-maximal inhibitory concentration: 15800 nM
Estimate against measurement, compound 3: 4.1-fold (0.61 log units) above; the measured number lies below the stated range.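

In this assay, hydrogen in place of chloro gives an at least 4.0-fold lower number from compound 1 to compound 3 (0.60 log units; beyond the scatter), and hydrogen in place of fluoro gives an at least 4.0-fold lower number from compound 2 to compound 3 (0.60 log units; beyond the scatter). This shows that the aromatic ring on the nitrogen can shift the read-out: the anilino compound 3 leaves the limit shared by the two halogen-bearing compounds, which the unreadable step between those two could not show. Both sizes remain minimum sizes, as each step starts from a limit of the assay and not from a number: the limit of > 64000 nM in this assay, at which 2 of the 3 values shown sit.

As far as these compounds go, the true distance of compound 3 from compound 1 and compound 2 stays open, as does any difference between those two halogen-bearing compounds. Also open, from the compounds shown here alone, is whether a methyl, a methoxy or an amine in place of the chloro of compound 1 would stay at the limit or reach the number of compound 3.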